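This account rests on a few compounds, and the source may have more. Where it says the series, first, only, none or still open, it means among the compounds named here.

Of the compounds shown here, two in this small set have been measured in an assay on Sf9 cells for inhibition of histone deacetylase 11 (Homo sapiens), read by fluorescence, tested at 0.5 uM; on this read-out lower numbers stand for less inhibition and higher numbers for more inhibition at the one concentration tested (going by the name of the read-out). Compound 1, `O=C(NO)c1ccc(-c2cn([C@H]3C[C@H](CO)N(CCCc4ccccc4)C3)nn2)cc1`, gives 18% in this assay. Among the compounds with values here, compound 2, `O=C(NO)c1cccc(-c2cn([C@@H]3C[C@H](CO)N(CCCc4ccccc4)C3)nn2)c1`, returns only a limit in this assay, < 10%, so its true inhibition is not known as a number; it is the one of the two values that sits at the limit of < 10% in this assay, at which 1 of the 2 values shown sits. Compound 2 therefore stands at the bottom of the numbers shown, with compound 1 the only measured point above the limit.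

Compound 3, `O=C(NO)c1ccc(-c2cn([C@@H]3C[C@H](CO)N(CCCc4ccccc4)C3)nn2)cc1`, has not yet been measured in this assay. It differs from compound 2 in one place: 4-(hydroxycarbamoyl)phenyl in place of 3-(hydroxycarbamoyl)phenyl on an aromatic carbon. Within the data shown here, no measured pair separated by this change alone exists here, so the direction of the step rests on compound 1, which carries a measured 18%. A small rise is expected, with the step of a number at least 5 percentage points higher from compound 2 to compound 3 (that floor lies within the scatter) estimated at roughly the size of the usual scatter. Compound 3 is therefore expected to give about 15%, most likely between 5% and 28%.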

Compound 3, a percentage reported as inhibition, at one concentration (the size of the read-out at that concentration, not a potency): 15%
For compound 3 middle estimate and measured number coincide at the digits printed; measured number inside the range.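

In this assay, 4-(hydroxycarbamoyl)phenyl in place of 3-(hydroxycarbamoyl)phenyl on an aromatic carbon of the five-membered aromatic ring gives a number at least 5 percentage points higher from compound 2 to compound 3 (that floor lies within the scatter), so this change can be read only as a floor that does not clear the scatter. Compound 2 holds only a limit of the assay: the limit of < 10% in this assay, at which 1 of the 3 values shown sits. The other new pair gives a number 3 percentage points lower from compound 1 to compound 3 (within the scatter), so the configuration drawn at that saturated ring carbon makes no difference beyond the scatter here: the fact that compounds 1 and 3 differ only in the configuration as drawn.

Going by these compounds, the true size of the change from 3-(hydroxycarbamoyl)phenyl to 4-(hydroxycarbamoyl)phenyl stays open, with no number for compound 2. Also open, on these data alone, is how a carboxylic acid in place of the hydroxycarbamoyl group would read in this assay at either of these two placements on the phenyl ring.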